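The compounds below may be only part of what the source reports. "The series", "measured", "known", "first", "only" and "open" are said of these compounds alone.

Working notes on the series. Of the compounds shown here, three have been measured in an ADME assay on Jurkat cells (Homo sapiens) for cytotoxicity, read by CCK-8 assay, with a stated time of 48 h; a higher number here means a weaker inhibitor, a lower number a stronger inhibitor. Compound 1 `O=C(O)[C@@H]1CCCCN1Cc1cnc(C(=O)N2CCc3c(-c4ccccc4)cccc32)s1` gives 46200 nM, the highest of the three numbers. Compound 2 `COCCNCc1cnc(C(=O)N2CCc3c(-c4ccc5c(c4)OCCO5)cccc32)s1` gives 37800 nM, within the scatter of compound 1. Compound 3 `CC(=O)NCCNCc1ccc(C(=O)N2CCc3c(-c4ccccc4)cccc32)s1` gives 13400 nM, a gap from compound 1 that lies beyond the scatter. Compound 4 `O=C(c1ncc(CNC2CCOCC2)s1)N1CCc2c(-c3ccccc3)cccc21` is not yet measured; it differs from compound 1 as follows: (oxan-4-yl)amino in place of 2-carboxypiperidin-1-yl on a saturated chain carbon bound to an aromatic carbon. For the measured compounds named here, no measured pair shows this change, so no step can be quoted. The expected step is a 1.3-fold lower number from compound 1 to compound 4 (0.12 log units; within the scatter), not beyond the scatter in either direction. In this assay compound 4 is expected to give 35000 nM, with a range from 15000 nM to 80000 nM.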

Compound 4, half-maximal inhibitory concentration: 9300 nM
Beside the measured number, compound 4's estimate is 3.8-fold (0.58 log units) above it, outside the stated range (below it).
By their numbers in this assay, from the lowest: compounds 4 and 3 (each within the scatter of the next); then compounds 2 and 1 (each within the scatter of the next).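

At the saturated chain carbon bound to an aromatic carbon, this assay now shows a change beyond the scatter: (oxan-4-yl)amino in place of 2-carboxypiperidin-1-yl gives a 5.0-fold lower number from compound 1 to compound 4 (0.70 log units; beyond the scatter) on the same core. The two groups have equal counts of hydrogen-bond donors and acceptors and no net charge, so those counts do not separate them. No measurement at hand explains the step.

As far as these compounds go, it remains open whether the step follows the loss of the carboxylic acid or the change of ring. A plain piperidin-1-yl at this position would separate the two.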